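A few compounds are considered here, and "the series" means these few. Any claim that something is new, unique, unknown or untested is made for them only; others in the source may bear on it.

compound 1 `CC(C)OC[C@H](Oc1ncnc2c1cnn2-c1ncccc1Cl)C(=O)Nc1ccc(Cl)cn1`: 3.5
compound 2 `CC(C)OC[C@H](Oc1ncnc2c1cnn2-c1ncccc1Cl)C(=O)Nc1ccccn1`: 2.5
compound 3 `CC(C)OC[C@H](Oc1ncnc2c1cnn2-c1ncccc1Cl)C(=O)Nc1ccc(F)cn1`: 2.7

In a physicochemical assay for lipophilicity (a lower number here means a more polar compound, a higher number a more lipophilic compound), compound 1 gives 3.5, compound 2 gives 2.5 and compound 3 gives 2.7. Compound 2 has the lowest number of the three. Its nearest neighbour is compound 3, separated by a number 0.20 log units higher from compound 2 to compound 3 (within the scatter); the furthest is compound 1, separated by a number 1.00 log units lower from compound 1 to compound 2 (beyond the scatter). The third measured step is a number 0.80 log units lower from compound 1 to compound 3 (beyond the scatter).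

Compound 4 `CC(C)OC[C@H](Oc1ncnc2c1cnn2-c1ccccc1Cl)C(=O)Nc1ccccn1` differs from compound 2 in one place: 2-chlorophenyl in place of 3-chloropyridin-2-yl on an aromatic nitrogen. None of the three measured steps bears directly on this change; each of them exchanges a substituent on an aromatic carbon of the ring carrying the amide, and none touches the group on the aromatic nitrogen of the core. The expectation therefore rests on the counted difference alone: the entering 2-chlorophenyl carries no hydrogen-bond acceptor where the leaving 3-chloropyridin-2-yl carried one. A step beyond the scatter, upward in this assay, is expected, of about a number 1.00 log units higher from compound 2 to compound 4 (beyond the scatter). For compound 4 the estimate is 3.5, with a range from 3 to 4.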

Compound 4, distribution coefficient: 3.5
Estimate against measurement, compound 4: no gap at the digits printed; the range from low to high includes it.
By their numbers in this assay, from the lowest: compounds 2 and 3 (each within the scatter of the next); then compounds 1 and 4 (each within the scatter of the next).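

Changing the group on the aromatic nitrogen of the core, which stays fixed across compounds 1 to 3, moves the read-out in this assay: 2-chlorophenyl in place of 3-chloropyridin-2-yl gives a number 1.00 log units higher from compound 2 to compound 4 (beyond the scatter). This position is therefore not silent in this assay, and the change that produces the step keeps the chlorine and the heavy-atom count while replacing the ring nitrogen with carbon and removing the counted hydrogen-bond acceptor. No measurement on hand accounts for the size or direction of this step.

On these data alone, it remains open whether the same exchange gives a comparable step with chloro or fluoro on the ring carrying the amide, as in compound 1 and compound 3. Also open, as far as these compounds go, is where an amine or a carboxylic acid in place of the chloro on the 2-chlorophenyl ring would fall in this assay.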